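This account rests on a few compounds, and the source may have more. Where it says the series, first, only, none or still open, it means among the compounds named here.

Compound 1 `CCCC(=O)Nc1c(C(O)(C(F)(F)F)C(F)(F)F)ccc2ccccc12` and compound 2 `O=C(Nc1c(C(O)(C(F)(F)F)C(F)(F)F)ccc2ccccc12)c1cccc(Cl)c1` share one core and differ only in the group on the carbonyl carbon. In an assay on LtK cells with ATP-sensitive inward rectifier potassium channel 11 (Homo sapiens) as the target (on this read-out higher numbers stand for an effect only at larger amounts of compound and lower numbers for an effect already at smaller amounts), compound 1 gives 131 nM. In this assay compound 2 gives 98 nM. Within the data shown here, the step of a 1.3-fold lower number from compound 1 to compound 2 (0.13 log units; within the scatter) is the only measured step here, and it lies within the scatter, so the two numbers are not distinguishable: compound 2 has the smaller of the two numbers, but its distance to compound 1 is no more than repeated measurements would show.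

Compound 3 `O=C(Nc1c(C(O)(C(F)(F)F)C(F)(F)F)ccc2ccccc12)c1ccc(OC(F)(F)F)cc1` carries a third group on the same carbonyl carbon. The change from compound 2 is 4-(trifluoromethoxy)phenyl in place of 3-chlorophenyl on a carbonyl carbon. Among the measured compounds shown here, the one step that bears on this place, a 1.3-fold lower number from compound 1 to compound 2 (0.13 log units; within the scatter), exchanged a propyl for a 3-chlorophenyl without moving the number beyond the scatter. From that single step a further exchange of the aryl group is expected to leave the number near that of compound 2; no direction can be supported. The step of a 1.0-fold higher number from compound 2 to compound 3 (0.01 log units; within the scatter) is therefore estimated to stay within the scatter. Compound 3 is estimated at 100 nM, in the range 40 nM to 250 nM.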

Compound 3, half-maximal effective concentration: > 10000 nM
Compound 3 was reported as a limit; the forecaster's own chance of this, stated with the estimate: 5%; middle value at least 100-fold (2.00 log units) from the limit.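

In this assay, the group on the carbonyl carbon proved able to matter far more than the first pair suggested: exchanging 3-chlorophenyl for 4-(trifluoromethoxy)phenyl gives an at least 100-fold higher number from compound 2 to compound 3 (2.00 log units; beyond the scatter), whereas propyl and 3-chlorophenyl lie within the scatter of each other. Against the propyl compound, the same group gives an at least 76-fold higher number from compound 1 to compound 3 (1.88 log units; beyond the scatter), so tolerance at this place does not extend to every aryl group, and having a six-membered aromatic ring there does not by itself settle the outcome. The value of compound 3 is a limit of the assay and not a number, and it is the only such value among the compounds shown: the limit of > 10000 nM in this assay, at which 1 of the 3 values shown sits.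

From the compounds shown here alone, how far the true number of compound 3 lies past that limit remains open, as does whether the trifluoromethoxy group itself or its place on the ring separates compound 3 from compound 2. Going by these compounds, it is also open whether a plain phenyl, a methoxyphenyl or a longer alkyl chain on the same carbonyl carbon would give a number near those of compound 1 and compound 2 or one like the limit of compound 3.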